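Chloro for hydrogen on a phenyl: compound 2 to compound 3

The source may hold more compounds than are shown below. What is called first, only, known or untested is meant among the compounds shown, and "the series" means these compounds.

Measured compounds:
compound 1 `O=C1OC(c2ccc(Cl)cc2)=C/C1=C\c1ccc([N+](=O)[O-])cc1` — 36%
compound 2 `O=C1/C(=C/c2ccccc2)C=C(c2ccc(Cl)cc2)N1Cc1ccccc1` — 37%

In a functional assay on the whole organism (strain Wistar) for inhibition, with Rattus norvegicus as the target, with stated times of 30 min and 3 h, at a dose of 20 mg/kg by the oral route (on this read-out lower numbers stand for less inhibition and higher numbers for more inhibition at the one dose given (going by the name of the read-out)), compound 1 gives 36%. Compound 2 gives 37% in this assay. Compound 2 holds the higher of the two numbers, with compound 1 as its nearest neighbour; the gap between them lies within the scatter of repeated measurements, so no order between the two can be read from these figures. Within the data shown here, the two compounds differ in more than one place, so no single-point step between measured compounds is available, and no size of step for a single change has been observed.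

Compound 3 `O=C1/C(=C/c2ccc(Cl)cc2)C=C(c2ccc(Cl)cc2)N1Cc1ccccc1` has not yet been measured in this assay. It differs from compound 2 by chloro in place of hydrogen on an aromatic carbon. Among the measured compounds shown here, with no measured step of this kind to rest on, the expectation for this assay is a change of no clear direction and of a size not beyond the scatter. Compound 3 is therefore expected to give about 40% in this assay, with an estimated range from 25% to 55%. The estimated step of a number 3 percentage points higher from compound 2 to compound 3 (within the scatter) is expected to stay within the scatter.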

Compound 3, a percentage reported as inhibition, in the whole organism at one dose (the size of the read-out at that dose, not a potency): 88.9%
Compound 3: the middle estimate sits 48.9 percentage points below what was measured; the whole stated range lies below it.
By their numbers in this assay, from the lowest: compounds 1 and 2 (each within the scatter of the next); then compound 3.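

In this assay, among these compounds, chloro in place of hydrogen on an aromatic carbon, para to a large group, gives the first single-point step, a number 51.9 percentage points higher from compound 2 to compound 3 (beyond the scatter), so this position is not indifferent to substitution at the one dose given. The change is small in count, 1 heavy atom with no ring, no hydrogen-bond donors or acceptors and no net charge, yet the shared core with phenyl and the same core with 4-chlorophenyl are clearly separated on this read-out. Nothing available bears on the reason for a step of this size.

Fluoro, methoxy, an amine or a carboxylic acid at the same place would show whether the step is specific to chloro or appears with other groups there, and the same change on the core of compound 1 would show whether it carries over to a different core. Since the read-out gives the size of the effect at one oral dose and not a potency, the compounds shown leave open how compound 2 and compound 3 would compare at other doses.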